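A few compounds are considered here, and "the series" means these few. Any claim that something is new, unique, unknown or untested is made for them only; others in the source may bear on it.

Compound 2 `Cc1nc2c3ccccc3ccc2c2nc3c(ccc4ccccc43)c(-c3ccccc3N)c12` is examined here on the shared core that it has in common with compound 1 `Cc1nc2c3ccccc3ccc2c2nc3c(ccc4ccccc43)c(-c3nccnc3N)c12` and compound 3 `Cc1nc2c3ccccc3ccc2c2nc3c(ccc4ccccc43)c(C)c12`. In a functional assay on AGS cells (Homo sapiens) for cytotoxicity, read by MTT assay, with a stated time of 48 h (a lower number here means a stronger inhibitor, a higher number a weaker inhibitor), compound 2 gives 12100 nM, the highest of the two numbers available. In this assay compound 1 gives 2260 nM. Compound 3 reaches only a limit of this assay, > 80000 nM, so that the limit of > 80000 nM in this assay, at which 1 of the 3 values shown sits, applies to it.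

The change to compound 4 `Cc1nc2c3ccccc3ccc2c2nc3c(ccc4ccccc43)c(-c3ccccc3)c12` is hydrogen in place of amino on an aromatic carbon; the same difference read one bond further out is 2-aminophenyl to phenyl. Within the data shown here, two measured steps bear on it. Replacing 3-aminopyrazin-2-yl by 2-aminophenyl gave a 5.4-fold higher number from compound 1 to compound 2 (0.73 log units; beyond the scatter), and replacing 2-aminophenyl by methyl gave an at least 6.6-fold higher number from compound 2 to compound 3 (0.82 log units; beyond the scatter). Both steps weaken the inhibition as the substituent on that aromatic carbon changes, and the second shows that losing the whole 2-aminophenyl group costs a great deal. Removing only the amino keeps the phenyl ring, so a smaller loss than in an at least 6.6-fold higher number from compound 2 to compound 3 (0.82 log units; beyond the scatter) is expected, but a loss beyond the scatter seems likely.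

Compound 4 is therefore expected to give about 30000 nM in this assay, within 10000 nM to 80000 nM. This estimate corresponds to a 2.5-fold higher number from compound 2 to compound 4 (0.39 log units; beyond the scatter).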

Compound 4, half-maximal inhibitory concentration: > 80000 nM
Compound 4 ended at the assay's limit (the forecaster's own chance of this, stated with the estimate: 25%); middle value at least 2.6-fold (0.42 log units) from the limit.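

Taking away only the amino gave an at least 6.6-fold higher number from compound 2 to compound 4 (0.82 log units; beyond the scatter), so the phenyl ring kept in compound 4 does not by itself retain the activity that compound 2 shows in this assay. The wider comparison reads an at least 35-fold higher number from compound 1 to compound 4 (1.54 log units; beyond the scatter), and among the compounds shown, only compound 1 and compound 2, which carry 3-aminopyrazin-2-yl and 2-aminophenyl, give a measured number rather than a limit. Compound 4 reaches only a limit of this assay, the step from compound 3 to compound 4 cannot be read, and methyl and phenyl therefore cannot be ranked against each other: the limit of > 80000 nM in this assay, at which 2 of the 4 values shown sit.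

Going by these compounds, the true size of the loss on removing the amino remains open, as does the question of whether the amino itself is needed or another group on that aromatic carbon could serve in its place. A hydroxyl, a methoxy or an aminomethyl group there would test this, and the compounds shown say nothing about how any of these would behave.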